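Methyl on the Phenyl Ring of Compound 2

The source may hold more compounds than are shown below. What is called first, only, known or untested is meant among the compounds shown, and "the series" means these compounds.

Measured compounds:
compound 1 `COc1ccccc1N1CCN(CCCn2c(=O)[nH]c3cc(-c4ccccc4)[nH]c3c2=O)CC1` — 1.23 nM
compound 2 `O=c1[nH]c2cc(-c3ccccc3)[nH]c2c(=O)n1CCCN1CCN(c2ccccc2Cl)CC1` — 62.4 nM
compound 3 `COc1ccccc1N1CCN(CCn2c(=O)[nH]c3cc(-c4cccc(Cl)c4)[nH]c3c2=O)CC1` — 19.3 nM

In an assay for binding affinity to Adrenergic receptor alpha-1 (Rattus norvegicus) (on this read-out lower numbers stand for stronger inhibition and higher numbers for weaker inhibition), compound 2 gives 62.4 nM, the highest number of the three. Within the data shown here, compound 3 sits nearest to it, and compound 1 lies furthest away, the step of a 51-fold higher number from compound 1 to compound 2 (1.71 log units; beyond the scatter) being the only single-point change among the measured compounds. Compound 4 `Cc1ccc(-c2cc3[nH]c(=O)n(CCCN4CCN(c5ccccc5Cl)CC4)c(=O)c3[nH]2)cc1` arises from compound 2 by methyl in place of hydrogen on an aromatic carbon. Among the measured compounds shown here, none of the measured steps touches this phenyl ring in a single change, so no measured step bears directly on the change; compound 3 differs from compound 2 in more than one place, and its value with that of compound 2 gives no isolated reading. Compound 4 is therefore expected to stay near compound 2, with the expected step of a 1.2-fold lower number from compound 2 to compound 4 (0.10 log units; within the scatter) not beyond the scatter, giving an estimated 50 nM with a range from 15 nM to 200 nM.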

Compound 4, inhibition constant: 110 nM
The estimate for compound 4 lay 2.2-fold (0.34 log units) below the measured number; the range from low to high includes it.
By their numbers in this assay, from the lowest: compound 1; then compound 3; then compounds 2 and 4 (each within the scatter of the next).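

Among these compounds, the step of a 1.8-fold higher number from compound 2 to compound 4 (0.25 log units; within the scatter) is the first single change on this phenyl ring, and in this assay it shows that going from phenyl to 4-methylphenyl, with the methyl para to a large group, stays within the scatter. No measurement is available that would explain this reading. Going by these compounds, whether an amine or a carboxylic acid at this same place would also stay within the scatter remains open. So does whether the methyl would read the same in compound 1, which carries methoxy in place of chloro.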